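The source may report more compounds than this note shows. Statements on the series, on what has been measured and on what is new or still open speak of the compounds shown alone.

In a functional assay on BGC-823 cells (Homo sapiens) for cytotoxicity, read by MTT assay (a lower number here means a stronger inhibitor, a higher number a weaker inhibitor), compound 2 `Cc1ccccc1Nc1nc(C)c(C(=O)/C=C/c2ccccc2)s1` gives > 25000 nM, which is a limit of the measurement and not a number. Compound 1 `COc1cccc(/C=C/C(=O)c2sc(Nc3ccccc3)nc2C)c1` gives a measured value in this assay of 14300 nM. Among the compounds with values here, compound 1 and compound 2 differ in more than one place, so their two values show only that one compound returned a number and the other a limit; the limit is where (the limit of > 25000 nM in this assay, at which 1 of the 2 values shown sits). Compound 3 `COc1cccc(/C=C/C(=O)c2sc(Nc3ccccc3C)nc2C)c1` has not yet been measured; it differs from compound 2 by methoxy in place of hydrogen on an aromatic carbon. Within the data shown here, no measured pair isolates this single change, so the size of the step is an expectation only: compound 1 also carries this methoxy group and gave 14300 nM, which suggests at most a small move toward stronger inhibition. Compound 3 is therefore expected to sit near 20000 nM, within 9000 nM to 50000 nM. The expected step is an at least 1.2-fold lower number from compound 2 to compound 3 (0.09 log units; that floor lies within the scatter).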

Compound 3, half-maximal inhibitory concentration: > 25000 nM
Compound 3 was reported as a limit; the forecaster's own chance of this, stated with the estimate: 40%; at least 1.2-fold (0.09 log units) between middle value and limit.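

Methoxy in place of hydrogen on an aromatic carbon cannot be sized here, because compound 2 and compound 3 both stand at a limit of the assay and not at a number: the limit of > 25000 nM in this assay, at which 2 of the 3 values shown sit. Within the data shown here, the one readable step comes from a different change, a single added methyl group, which gives an at least 1.7-fold higher number from compound 1 to compound 3 (0.24 log units; that floor lies within the scatter). That floor does not by itself separate the two compounds, though the true gap could be larger.

On these data alone, it remains open whether the methoxy group changes the read-out in this assay at all when the compounds on both sides of the change give numbers. Also open, as far as these compounds go, is whether an amine or a carboxylic acid in place of the methoxy would bring compound 3 to a measured value.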